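A few compounds are considered here, and "the series" means these few. Any claim that something is new, unique, unknown or untested is made for them only; others in the source may bear on it.

Compound 2 `CCOC(=O)C1=Cc2ccccc2OC1(OCc1cn(CC(=O)Nc2cccc(Cl)c2)nn1)C(F)(F)F` gives 12800 nM in a functional assay on A549 cells (Homo sapiens) for inhibition, read by MTT assay, with a stated time of 24 h (on this read-out lower numbers stand for stronger inhibition and higher numbers for weaker inhibition), and holds the higher of the two numbers shown, its nearest neighbour being compound 1 `CCOC(=O)C1=Cc2ccccc2OC1(OCc1cn(-c2ccc(F)cc2)nn1)C(F)(F)F`, which gives 7300 nM; the step of a 1.8-fold higher number from compound 1 to compound 2 (0.24 log units; within the scatter) stays within the scatter. Compound 3 `CCOC(=O)C1=Cc2ccccc2OC1(OCc1cc(-c2ccc(C)cc2)no1)C(F)(F)F` is reported only as a limit, > 150000 nM. The unmeasured compound 4 `CCOC(=O)C1=Cc2ccccc2OC1(OCc1cn(-c2cccc(OC)c2)nn1)C(F)(F)F` differs from compound 2 by 3-methoxyphenyl in place of ((3-chlorophenyl)carbamoyl)methyl on an aromatic nitrogen. Among the measured compounds shown here, the only measured step bearing on this, a 1.8-fold higher number from compound 1 to compound 2 (0.24 log units; within the scatter), exchanged an aryl group on that same nitrogen for the carbamoylmethyl chain without moving beyond the scatter. The change here returns to an aryl group, so the expected step is a 1.6-fold lower number from compound 2 to compound 4 (0.20 log units; within the scatter), nothing beyond the scatter. Compound 4 is therefore estimated at 8000 nM, with a range from 3000 nM to 25000 nM.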

Compound 4, half-maximal inhibitory concentration: > 150000 nM
Compound 4 ended at the assay's limit; the forecaster's own chance of this, stated with the estimate: 10%; middle value at least 18-fold (1.27 log units) away from the limit.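

On the aromatic nitrogen, an aryl group alone does not secure activity: 3-methoxyphenyl in place of 4-fluorophenyl gives an at least 20-fold higher number from compound 1 to compound 4 (1.31 log units; beyond the scatter). The same group in place of ((3-chlorophenyl)carbamoyl)methyl gives an at least 11-fold higher number from compound 2 to compound 4 (1.06 log units; beyond the scatter), so this position, which showed no change beyond the scatter between the earlier pair, responds strongly to the group it carries. The value of compound 4 is a limit in this assay: the limit of > 150000 nM in this assay, at which 2 of the 4 values shown sit.

The compounds shown do not separate the methoxy group from its place on the phenyl ring. Unsubstituted phenyl and 4-methoxyphenyl on the same nitrogen remain open.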